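Swapping Trifluoromethyl for Methoxy: Expected Solubility of Compound 3

The compounds below may be only part of what the source reports. "The series", "measured", "known", "first", "only" and "open" are said of these compounds alone.

Two measured compounds share one core and differ at a single aromatic carbon. Compound 1 `C=CC(=O)N1CC[C@H](N2C(=O)N(c3ccccc3)Cc3cnc(Nc4ccc(N5CCN(C)CC5)c(Cl)c4)nc32)C1` carries a chloro group there, and in a physicochemical assay for solubility, read by HPLC, in phosphate buffer, measured as thermodynamic solubility, with a stated time of 24 h, at pH 6.8 (a lower number here means a less soluble compound, a higher number a more soluble compound), compound 1 gives 215 ug/mL. Compound 2 `C=CC(=O)N1CC[C@H](N2C(=O)N(c3ccccc3)Cc3cnc(Nc4ccc(N5CCN(C)CC5)c(C(F)(F)F)c4)nc32)C1` carries a trifluoromethyl group in the same place, and in this assay compound 2 gives 60.9 ug/mL. Within the data shown here, the one measured step, a 3.5-fold lower number from compound 1 to compound 2 (0.55 log units; beyond the scatter), leaves compound 2 with the lower of the two numbers, compound 1 being its only neighbour.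

Compound 3 `C=CC(=O)N1CC[C@H](N2C(=O)N(c3ccccc3)Cc3cnc(Nc4ccc(N5CCN(C)CC5)c(OC)c4)nc32)C1` changes that same carbon once more: methoxy in place of trifluoromethyl on an aromatic carbon. Among the measured compounds shown here, the only step that bears on this is a 3.5-fold lower number from compound 1 to compound 2 (0.55 log units; beyond the scatter), which shows that compound 2, the one carrying the trifluoromethyl group, sits lowest. Taking that group away again is expected to move the number back upward, by about the size of that step, but no measured pair contains a methoxy group, so the range must be kept wide. In this assay compound 3 is expected to give 250 ug/mL, between 90 ug/mL and 600 ug/mL. The expected step is a 4.1-fold higher number from compound 2 to compound 3 (0.61 log units; beyond the scatter).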

Compound 3, solubility: 256 ug/mL
Compound 3: the middle estimate sits 1.0-fold (0.01 log units) below what was measured, within the range that was stated.
By their numbers in this assay, from the lowest: compound 2; then compounds 1 and 3 (each within the scatter of the next).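

In this assay, methoxy in place of trifluoromethyl on this aromatic carbon gives a 4.2-fold higher number from compound 2 to compound 3 (0.62 log units; beyond the scatter) and so sets the low number of compound 2 against a second group, where before there was only chloro to compare it with. Methoxy in place of chloro gives a 1.2-fold higher number from compound 1 to compound 3 (0.08 log units; within the scatter) and so leaves compound 1 and compound 3 indistinguishable in this read-out, which makes trifluoromethyl the only one of the three groups at this position whose compound stands apart, even though methoxy and trifluoromethyl differ in their heavy atoms and in their hydrogen-bond acceptor count. No measurement at hand accounts for why the trifluoromethyl compound stands apart from the other two.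

The compounds shown leave open whether another group on this carbon, such as an amine, a carboxylic acid or a longer chain like ethoxy, would give a number in line with compound 1 and compound 3 or one in line with compound 2. They also leave open whether the same order of groups would hold if the 4-methylpiperazin-1-yl group were replaced by a morpholine.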